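Nitro for trifluoromethyl on the shared core

A few compounds are considered here, and "the series" means these few. Any claim that something is new, unique, unknown or untested is made for them only; others in the source may bear on it.

Compound 1 `Oc1noc2cccc(Nc3cccc(C(F)(F)F)c3)c12` stands only at a limit: in an ADME assay on isolated protein for inhibition of cytochrome c oxidase subunit 2 (Homo sapiens), read by ELISA (on this read-out higher numbers stand for weaker inhibition and lower numbers for stronger inhibition), compound 1 gives > 100000 nM, a limit of the assay and not a number. Compound 2 `Oc1noc2cccc(Nc3cc(C(F)(F)F)cc(C(F)(F)F)c3)c12` likewise gives > 100000 nM in this assay, also a limit. The step that the two limits leave unreadable from compound 1 to compound 2 therefore cannot be read, since both values sit at the limit of > 100000 nM in this assay, at which 2 of the 2 values shown sit. Compound 3 `O=[N+]([O-])c1cccc(Nc2cccc3onc(O)c23)c1` carries nitro in place of trifluoromethyl on an aromatic carbon. For the measured compounds named here, no measured step bears on this change, and nothing points away from the limit. Compound 3 is expected to give 200000 nM (range 50000 nM to 1000000 nM) in this assay, an expected step that the limit leaves unreadable from compound 1 to compound 3.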

Compound 3, half-maximal inhibitory concentration: > 100000 nM
Compound 3 gave a limit, no number; the forecaster's own chance of this, stated with the estimate: 85%; the middle value does not contradict the limit.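

Compound 1 and compound 3 both stand only at a limit in this assay, so no step between them can be read: the limit of > 100000 nM in this assay, at which 3 of the 3 values shown sit.

The compounds shown leave open whether any group on the shared core brings a measurable value in this assay.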